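Extending the benzylic amine of a melanocortin receptor 4 ligand

This account rests on a few compounds, and the source may have more. Where it says the series, first, only, none or still open, it means among the compounds named here.

Measured compounds:
compound 1, `CC[C@H](C)C(N)c1cc(C(F)(F)F)ccc1N1CCN(C(=O)CCc2ccc(Cl)cc2Cl)CC1`: 75 nM
compound 2, `CCC(C)[C@H](N)c1cc(C(F)(F)F)ccc1N1CCN(C(=O)CCc2ccc(OC)c(OC)c2Cl)CC1`: 2500 nM
compound 3, `CC(C)C[C@H](N)c1cc(C(F)(F)F)ccc1N1CCN(C(=O)CCc2cn(C)c3ccccc23)CC1`: 3000 nM

Of the compounds shown here, three sharing one core have been measured in an assay on HEK293 cells for displacement of a labelled ligand from Melanocortin receptor 4 (Homo sapiens); on this read-out lower numbers stand for stronger inhibition and higher numbers for weaker inhibition. Compound 1 gives 75 nM and is the most potent of the three, with compound 2 at 2500 nM and compound 3 at 3000 nM both well beyond the usual scatter above it. Among the measured compounds shown here, the two weaker compounds differ from compound 1 in more than one place, so no single step between measured compounds can be read from them.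

Compound 4, `CCC(C)[C@H](NCCN)c1cc(C(F)(F)F)ccc1N1CCN(C(=O)CCc2ccc(Cl)cc2Cl)CC1`, has not been measured. It differs from compound 1 in one place: 1-((2-aminoethyl)amino)-2-methylbutyl in place of 1-amino-2-methylbutyl on an aromatic carbon. The change keeps the acyl piperazine portion of compound 1 untouched and only lengthens the substituent that carries the stereocentre.

For the measured compounds named here, with no measured step of this kind to lean on, the size of the change is uncertain. It is expected that the step from compound 1 to compound 4 is modest, a 1.6-fold higher number from compound 1 to compound 4 (0.20 log units; within the scatter), and may not exceed the scatter. Compound 4 is therefore estimated at 120 nM, within a range of 30 nM to 500 nM.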

Compound 4, inhibition constant: 56 nM
Estimate against measurement, compound 4: 2.1-fold (0.33 log units) above, within the range that was stated.
By their numbers in this assay, from the lowest: compounds 4 and 1 (each within the scatter of the next); then compounds 2 and 3 (each within the scatter of the next).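

In this assay, putting 1-((2-aminoethyl)amino)-2-methylbutyl in place of 1-amino-2-methylbutyl on this aromatic carbon gives a 1.3-fold lower number from compound 1 to compound 4 (0.13 log units; within the scatter). Among the compounds shown here, this is the first single-place step, and it shows that this position takes the longer substituent, with its second nitrogen and its added donor and acceptor, with no change in binding beyond the scatter. The compounds shown hold no measurement that accounts for this result.

As far as these compounds go, it remains open whether the terminal amine of the added chain matters, since neither a plain ethyl group nor a hydroxyethyl group on the benzylic nitrogen appears here, nor a carboxylic acid at the chain end. From the compounds shown here alone, a longer chain, such as 3-aminopropyl, and the same extension on the other acyl groups of the series are also open.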